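The source may report more compounds than this note shows. Statements on the series, on what has been measured and on what is new or still open speak of the compounds shown alone.

Measured so far in a functional assay on HL-60 cells (Homo sapiens) for cytotoxicity, read by WST assay, with a stated time of 48 h; a higher number here means a weaker inhibitor, a lower number a stronger inhibitor:
- compound 1 `O[C@@H](c1ccccc1)[C@H]1CO[C@H](c2ccccc2)[C@@H](C/C=C/c2ccccc2)C1` gives 7040 nM
- compound 2 `O[C@@H](c1ccccc1)[C@H]1CO[C@H](c2ccccc2)[C@@H](C/C=C/C2CCCCC2)C1` gives 6260 nM

Among the measured compounds shown here, compound 2 holds one of only two numbers, and the other sits level with it. For the measured compounds named here, the single step between them (a 1.1-fold lower number from compound 1 to compound 2 (0.05 log units; within the scatter)) stays within the scatter.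

Next is compound 3 `O[C@@H](c1ccccc1)[C@H]1CO[C@H](c2ccccc2)[C@@H](C/C=C/c2ccccc2F)C1`, not yet measured in this assay and differing from compound 2 by one group (2-fluorophenyl in place of cyclohexyl on a double-bonded chain carbon bound to a double-bonded chain carbon). It has 2-fluorophenyl in place of cyclohexyl on a double-bonded chain carbon bound to a double-bonded chain carbon.

Going by the values given here, only one measured step bears on this place, the exchange of phenyl and cyclohexyl (a 1.1-fold lower number from compound 1 to compound 2 (0.05 log units; within the scatter)), and it was small. Among the compounds with values here, no measured compound carries fluorine, so that part of the change has no measured guide. On this thin evidence, no shift beyond the scatter is expected in either direction.

The expected step is small (a 1.0-fold lower number from compound 2 to compound 3 (0.02 log units; within the scatter)) and is an estimate only. For compound 3 the estimated value is 6000 nM within an expected range of 3000 nM to 12000 nM on present data.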

Compound 3, half-maximal inhibitory concentration: 9530 nM
The estimate for compound 3 lay 1.6-fold (0.20 log units) below the measured number, within the range that was stated.
By their numbers in this assay, from the lowest: compounds 2, 1 and 3 (each within the scatter of the next).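

In this assay, among the compounds shown here, fluoro in place of hydrogen on an aromatic carbon gives a 1.4-fold higher number from compound 1 to compound 3 (0.13 log units; within the scatter), the first reading on a substituted aromatic ring at this place. Set against the non-aromatic ring, 2-fluorophenyl in place of cyclohexyl on a double-bonded chain carbon bound to a double-bonded chain carbon gives a 1.5-fold higher number from compound 2 to compound 3 (0.18 log units; within the scatter). With both steps inside the scatter, the three rings shown at this place, phenyl, cyclohexyl and 2-fluorophenyl, read level with one another, so neither the fluorine nor the exchange of ring type has a resolved effect in this assay. No supporting data are available to explain this result.

As far as these compounds go, whether any group at this place can move the number beyond the scatter remains open; an amine or a carboxylic acid in place of the fluoro, or a longer chain carrying the ring, would bear on that question. The shared core is constant in the compounds shown, so they say nothing about changes elsewhere on it.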